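Para-substituted anilino series: cyclohexyl replaced by piperidine

The source may report more compounds than this note shows. Statements on the series, on what has been measured and on what is new or still open speak of the compounds shown alone.

Among the compounds with values here, compound 2 `O=C1C(Nc2ccc(C3CCCCC3)cc2)=CC(=O)c2ncncc21` gives the lowest number of the three measured so far in a functional assay on BXPC-3 cells (Homo sapiens) for cytotoxicity, read by MTT assay, with a stated time of 72 h (a higher number here means a weaker inhibitor, a lower number a stronger inhibitor), at 500 nM. Compound 3 `CC1=C(Nc2ccc(N3CCN(C)CC3)cc2)C(=O)c2cncnc2C1=O` sits within the scatter of it at 870 nM, so no order between the two can be claimed. Compound 1 `O=C1C(Nc2cccc(-c3ccccc3)c2)=CC(=O)c2ncncc21`, at 5100 nM, lies beyond the scatter from compound 2. Compound 4 `O=C1C(Nc2ccc(N3CCCCC3)cc2)=CC(=O)c2ncncc21` has not yet been measured in this assay. It differs from compound 2 as follows: piperidin-1-yl in place of cyclohexyl on an aromatic carbon. Within the data shown here, no measured pair isolates this change. Compound 3 carries a nitrogen-containing ring at the same kind of position and stays close to compound 2, so a small step is expected, not beyond the scatter; the expected step is a 1.3-fold higher number from compound 2 to compound 4 (0.11 log units; within the scatter). Compound 4 is estimated at 650 nM, ranging from 250 nM to 1700 nM.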

Compound 4, half-maximal inhibitory concentration: 2500 nM
Beside the measured number, compound 4's estimate is 3.8-fold (0.59 log units) below it; the measured number lies above the stated range.
By their numbers in this assay, from the lowest: compounds 2 and 3 (each within the scatter of the next); then compound 4; then compound 1.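

In this assay, within the data shown here, piperidin-1-yl in place of cyclohexyl gives a 5.0-fold higher number from compound 2 to compound 4 (0.70 log units; beyond the scatter), the first step that isolates this change on the aromatic carbon. This position therefore distinguishes between two six-membered non-aromatic rings of equal heavy-atom count, one of carbon only and the other with a ring nitrogen and a hydrogen-bond acceptor. No available data bear on the cause of this step. Going by these compounds, whether morpholin-4-yl or an open-chain dimethylamino group at this place would fall nearer compound 2 or compound 4 remains open.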